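The compounds below may be only part of what the source reports. "The series", "measured", "known", "first", "only" and "open" are said of these compounds alone.

Compound 1: `c1ccc(Sc2ncnc3[nH]cnc23)cc1`, 0%
Compound 2: `Fc1ccc(Cn2cnc3c(Cl)ncnc32)cc1`, 0%
Compound 3: `c1ccc(Cn2cnc3c(Sc4ccccc4)ncnc32)cc1`, 3%

All three measured compounds were tested in an assay on isolated protein for inhibition of Ca2+/calmodulin-dependent protein kinase II (CaM kinase II) (Rattus norvegicus), tested at 30 uM; on this read-out higher numbers stand for more inhibition at the one concentration tested (going by the name of the read-out) and lower numbers for less inhibition. In this assay compound 1 gives 0%, compound 2 gives 0%, and compound 3 gives 3%. Compound 3 thus has the highest of the three numbers, but its gaps to compound 1 and to compound 2 are both within the scatter, so none of the three can be set apart from the others.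

Going by the values given here, the only step between measured compounds that differ in one place is a number 3 percentage points higher from compound 1 to compound 3 (within the scatter). Adding the benzyl group therefore changed nothing beyond the scatter.

Compound 4, `Fc1ccc(Cn2cnc3c(Sc4ccccc4)ncnc32)cc1`, is the next compound to be measured. It differs from compound 3 by fluoro in place of hydrogen on an aromatic carbon. Compound 2 already carries this 4-fluorobenzyl group, on a core with chloro rather than the sulfur-linked phenyl, and shows no inhibition.

Among the compounds with values here, no measured step touches this particular change, and every measured number sits near the bottom of the scale. The expected step is a number 1 percentage points lower from compound 3 to compound 4 (within the scatter), meaning no change beyond the scatter. Compound 4 is therefore estimated to give 2%, with a range from -6% to 12%.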

Compound 4, a percentage reported as inhibition, at one concentration (the size of the read-out at that concentration, not a potency): 0%
The estimate for compound 4 lay 2 percentage points above the measured number; measured number inside the range.
By their numbers in this assay, from the lowest: compounds 1, 2, 4 and 3 (each within the scatter of the next).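

In this assay, fluoro in place of hydrogen on an aromatic carbon, para to a large group, gives a number 3 percentage points lower from compound 3 to compound 4 (within the scatter), the first direct test of this change and one that shows no effect beyond the scatter. Going by these compounds alone, the two other new comparisons agree: phenylsulfanyl in place of chloro gives no change at the digits printed from compound 2 to compound 4 (within the scatter), and 4-fluorobenzyl in place of hydrogen on an aromatic nitrogen gives no change at the digits printed from compound 1 to compound 4 (within the scatter), so none of the single changes in these four compounds separates one from another. No independent measurement is available to help interpret this flat result.

All four numbers sit near the bottom of the scale, so these compounds cannot show whether fluoro would make a difference on a compound with clear inhibition at the one concentration tested. Going by these compounds, it also remains open how this assay would read with an amine or a carboxylic acid at this place on the benzyl ring, or with a longer chain in place of the benzyl group.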